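Shortening the allyl to ethyl on the pyrazole amine

A few compounds are considered here, and "the series" means these few. Any claim that something is new, unique, unknown or untested is made for them only; others in the source may bear on it.

Compound 3 `C=CCNc1[nH]nc(N)c1C(=O)Nc1ccc(OCC)cc1` is reported in an ADME assay on TERT-RPE1 cells (Homo sapiens) for cytotoxicity, read by resazurin assay, with a stated time of 48 h (on this read-out lower numbers stand for stronger inhibition and higher numbers for weaker inhibition), only as a limit, > 100000 nM. Compound 1 `CCOc1ccc(NC(=O)c2c(N)n[nH]c2NC)cc1` likewise reaches only a limit in this assay, > 100000 nM. Compound 2 `CCOc1ccc(NC(=O)c2c(N)n[nH]c2Nc2ccccc2)cc1` gives a number in this assay, 67800 nM. Two of the measured steps end at the limit, the limit of > 100000 nM in this assay, at which 2 of the 3 values shown sit: one is an at least 1.4-fold lower number from compound 1 to compound 2 (0.16 log units; that floor lies within the scatter), the other at least 1.4-fold higher number from compound 2 to compound 3 (0.16 log units; that floor lies within the scatter). The remaining step, a step that the two limits leave unreadable from compound 1 to compound 3, alters the same place as the change considered here, but its two limits leave it unreadable.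

Compound 4 `CCNc1[nH]nc(N)c1C(=O)Nc1ccc(OCC)cc1` differs from compound 3 in one place: methyl in place of vinyl on a saturated chain carbon bound to a nitrogen on an aromatic ring. Among the measured compounds shown here, the only measured step at that place, a step that the two limits leave unreadable from compound 1 to compound 3, gives no readable size, and the two steps involving phenyl stay within the usual scatter. The expected step is therefore a step that the limit leaves unreadable from compound 3 to compound 4, no change beyond the scatter. Compound 4 is estimated at 150000 nM, between 50000 nM and 500000 nM, and is expected most likely to appear again only as a limit.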

Compound 4, half-maximal inhibitory concentration: > 100000 nM
Compound 4 ended at the assay's limit; the forecaster's own chance of this, stated with the estimate: 75%; the middle value is on the limit's open side.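

Ethyl on the nitrogen on an aromatic ring leaves compound 4 at the limit of this assay, so the methyl, allyl and ethyl compounds now all sit there, with compound 2, the phenyl compound, as the only one giving a number: the limit of > 100000 nM in this assay, at which 3 of the 4 values shown sit. Ethyl in place of phenyl gives an at least 1.4-fold higher number from compound 2 to compound 4 (0.16 log units; that floor lies within the scatter), so this second comparison with phenyl again shows no difference beyond the scatter. The steps to compound 4 from compound 1 and from compound 3 cannot be read.

The compounds shown leave open whether phenyl truly differs from the small chains in this assay, and how compound 1, compound 3 and compound 4 compare with one another beyond the limit. From the compounds shown here alone, it also remains open whether a longer chain such as butyl, or a benzyl group, on that nitrogen would give a readable number.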